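From methoxy to isopropoxy in compound 2

The source may hold more compounds than are shown below. What is called first, only, known or untested is meant among the compounds shown, and "the series" means these compounds.

compound 1 (`COc1cc(-c2ncnn2-c2cccc(F)c2)cc(OC)c1OC`): > 10000 nM as a limit
compound 2 (`COc1ccc(-c2ncnn2-c2cc(OC)c(OC)c(OC)c2)cc1`): 520 nM as a number
compound 3 (`COc1ccc(-n2ncnc2-c2cc(OC)c(OC)c(OC)c2)cc1`): > 10000 nM as a limit

In a functional assay on A549 cells (Homo sapiens) for antiproliferative activity, read by MTT assay, with a stated time of 72 h (on this read-out lower numbers stand for stronger inhibition and higher numbers for weaker inhibition), compound 2 gives 520 nM as the only number shown. The other measurements rest on the limit of > 10000 nM in this assay, at which 2 of the 3 values shown sit, and offer no further number. Compound 4 (`COc1cc(-n2ncnc2-c2ccc(OC(C)C)cc2)cc(OC)c1OC`) carries isopropyl in place of methyl on an oxygen on an aromatic ring relative to compound 2, isopropyl in place of methyl on an oxygen on an aromatic ring. Among the measured compounds shown here, the one measured step is a step that the two limits leave unreadable from compound 1 to compound 3 and it lies at another place, so no measured step gives a size for this change. With compound 2 at 520 nM as the sole reference, a moderate weakening in this assay is only a tentative expectation. The expected step is a 2.9-fold higher number from compound 2 to compound 4 (0.46 log units; beyond the scatter) toward weaker inhibition. For compound 4 the estimate is 1500 nM with an expected range of 350 nM to 8000 nM in this reading.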

Compound 4, half-maximal inhibitory concentration: > 10000 nM
Compound 4 was reported as a limit (the forecaster's own chance of this, stated with the estimate: 20%); middle value at least 6.6-fold (0.82 log units) away from the limit.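

In this assay, among the compounds shown here, replacing methoxy with isopropoxy on this oxygen gives an at least 19-fold higher number from compound 2 to compound 4 (1.28 log units; beyond the scatter), the first step with a readable size. Compound 4 reaches only a limit, so its true value and the full size of the step remain unknown: the limit of > 10000 nM in this assay, at which 3 of the 4 values shown sit.

At this place, therefore, the methoxy of compound 2 keeps a measurable number, while the isopropoxy does not. On these data alone, it remains open whether ethoxy or a hydroxyl group at the same oxygen would keep a number, and so where along this change the activity is lost.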